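The source may hold more compounds than are shown below. What is called first, only, known or untested is meant among the compounds shown, and "the series" means these compounds.

Compound 1, whose structure is `C=C1C(=O)O[C@@H]2[C@@H]1[C@H](OC(=O)C(C)C)C(=O)[C@@H](C)C[C@H](O)C[C@](C)(O)[C@H]2OC(=O)/C(C)=C\C`, was tested in a functional assay on A549 cells (Homo sapiens) for cytotoxicity, read by sulforhodamine B assay (a higher number here means that more compound is needed for the effect, a lower number that less compound is needed), where compound 1 gives 3.12 ug/mL. Compound 2, `C=C1C(=O)O[C@@H]2[C@@H]1[C@H](OC(=O)C(C)C)C(=O)[C@@H](C)C[C@H](O)C[C@](C)(O)[C@H]2OC(=O)C(C)C`, differs from compound 1 only in one group on a carbonyl carbon, and in this assay compound 2 gives 8.36 ug/mL. That single change produced a 2.7-fold higher number from compound 1 to compound 2 (0.43 log units; beyond the scatter), so more compound 2 than compound 1 was needed for the same effect. Among the two compounds measured, compound 2 therefore stands with the highest number, and its only neighbour is compound 1.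

Compound 3, `C=C1C(=O)O[C@@H]2[C@@H]1[C@H](OC(=O)C(C)CC)C(=O)[C@@H](C)C[C@H](O)C[C@](C)(O)[C@H]2OC(=O)C(C)C`, has not yet been measured. It is obtained from compound 2 by a small addition: methyl in place of hydrogen on a saturated chain carbon, two bonds along the chain from a carbonyl carbon. Within the data shown here, the one measured step, from compound 1 to compound 2, swapped a whole group on a carbonyl carbon and was modest in size; no step in this set adds a single methyl on a chain. With so little to go on, the expected step of a 1.0-fold lower number from compound 2 to compound 3 (0.02 log units; within the scatter) is taken to lie within the usual scatter of this assay, in no firm direction. On that basis compound 3 is estimated at 8 ug/mL, with a plausible range from 3.5 ug/mL to 18 ug/mL.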

Compound 3, concentration for half-maximal effect: 3.71 ug/mL
Estimate against measurement, compound 3: 2.2-fold (0.33 log units) above; the range from low to high includes it.
By their numbers in this assay, from the lowest: compounds 1 and 3 (each within the scatter of the next); then compound 2.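

Among these compounds, until now the only measured step swapped a whole group on a carbonyl carbon. This result shows that something much smaller, turning isopropyl into sec-butyl by adding one methyl on a saturated chain carbon, two bonds along the chain from a carbonyl carbon, is enough to move the number in this assay beyond the scatter: a 2.3-fold lower number from compound 2 to compound 3 (0.35 log units; beyond the scatter). Less compound is needed for the same effect, so this chain is not a place where a single added carbon goes unnoticed, at least in this pair of compounds. No measurement offered here explains why the added methyl has this effect.

The compounds shown leave open whether the number would keep falling with a longer chain such as a pentyl group, or whether a hydroxyl group or an amine on this same chain would keep the effect or lose it. They also leave open whether the same methyl would give a similar step on a compound carrying the 1-methylprop-1-en-1-yl group of compound 1, where only a new measurement could tell.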